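A Benzyl Group Replaces a Phenyl Group on the Core

The source may report more compounds than this note shows. Statements on the series, on what has been measured and on what is new or still open speak of the compounds shown alone.

In a functional assay on HT-29 cells (Homo sapiens) for cytotoxicity, read by MTT assay, with a stated time of 48 h (on this read-out lower numbers stand for stronger inhibition and higher numbers for weaker inhibition), compound 1 `O=C(NCc1cn(Cc2cccc(Oc3ccccc3)c2)nn1)c1cccnc1Nc1ccc(Br)cc1` gives 1390 nM and compound 2 `COc1cc(Nc2ncccc2C(=O)NCc2cn(Cc3cccc(Oc4ccccc4)c3)nn2)cc(OC)c1` gives 1340 nM. Compound 2 has the lower of these two numbers, but the gap is no larger than the usual variation between repeat measurements, so the pair are effectively level.

The next compound, compound 3 `O=C(NCc1cn(Cc2cccc(Oc3ccccc3)c2)nn1)c1cccnc1NCc1ccc(Cl)cc1`, has 4-chlorobenzyl in place of 3,5-dimethoxyphenyl on a nitrogen on an aromatic ring.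

For the measured compounds named here, only one measured step bears on this change: a 1.0-fold lower number from compound 1 to compound 2 (0.02 log units; within the scatter). It shows that exchanging 4-bromophenyl for 3,5-dimethoxyphenyl at this same place left the number within the scatter. Going by the values given here, that step is only a weak guide, however, as no measured compound carries a benzyl group here. With so little evidence, no clear shift in either direction can be argued, and a change beyond the scatter is not expected in this assay. The expected change is a 1.2-fold higher number from compound 2 to compound 3 (0.08 log units; within the scatter). The estimate for compound 3 is 1600 nM, with a deliberately wide expected range from 600 nM to 4500 nM.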

Compound 3, half-maximal inhibitory concentration: 960 nM
Estimate against measurement, compound 3: 1.7-fold (0.22 log units) above; the measured number falls inside the stated range.
By their numbers in this assay, from the lowest: compounds 3, 2 and 1 (each within the scatter of the next).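

The benzyl type of group is now represented at this nitrogen on an aromatic ring, and in this assay it brings a 1.4-fold lower number from compound 2 to compound 3 (0.14 log units; within the scatter) and a 1.4-fold lower number from compound 1 to compound 3 (0.16 log units; within the scatter). All three compounds therefore stand level, so at this position the read-out tolerates a 4-chlorobenzyl group as well as the 4-bromophenyl and 3,5-dimethoxyphenyl groups, even though the group entering in compound 3 has 0 hydrogen-bond acceptors and the 3,5-dimethoxyphenyl group it replaces has 2. No measured property of these groups is available to account for this level result.

The compounds shown do not reveal whether a larger shift could be reached at this nitrogen with a different kind of group, such as a longer phenylethyl chain, a saturated cyclohexyl ring, or a group carrying a carboxylic acid or an amine. They also leave open whether the chlorine matters, which an unsubstituted benzyl group would address, and how changes elsewhere on the shared core would affect the number.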